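Swapping the Aryl Group on a Shared Core

The compounds below may be only part of what the source reports. "The series", "measured", "known", "first", "only" and "open" are said of these compounds alone.

Of the compounds shown here, three built on one shared core have been measured in an ADME assay on microsomes from liver (Homo sapiens) for metabolic stability; on this read-out lower numbers stand for slow clearance and higher numbers for fast clearance. Compound 1 `CNC(=O)CN1CCC(c2cc3c(-c4ccc(=O)n(C(C)C)c4)ccnc3[nH]2)CC1` gives 8.6 uL/min. Compound 2 `CC(C)n1cc(-c2ccnc3[nH]c(C4CCN(CC(=O)N5CCCC5)CC4)cc23)ccc1=O` gives 45 uL/min. Compound 3 `COc1cc(F)ccc1-c1ccnc2[nH]c(C3CCN(CC(=O)N(C)C)CC3)cc12` gives 14 uL/min. Among these three, compound 3 holds the second highest number: compound 1 is the nearest, and the two lie within the scatter of each other, while compound 2 is the furthest, beyond the scatter.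

Within the data shown here, the only step that joins two measured compounds through a single change is a 5.2-fold higher number from compound 1 to compound 2 (0.72 log units; beyond the scatter); it alters the amide portion, not the aromatic group attached to the core.

Compound 4 `CC(C)n1nc(-c2ccnc3[nH]c(C4CCN(CC(=O)N(C)C)CC4)cc23)ccc1=O` has not yet been measured. It differs from compound 3 in one place: a group of 10 heavy atoms (7 carbon, 2 nitrogen, 1 oxygen; one six-membered aromatic ring with 2 hetero atoms) in place of a group of 9 heavy atoms (7 carbon, 1 oxygen, 1 fluorine; one six-membered aromatic ring of carbon only), on an aromatic carbon.

Among the measured compounds shown here, no measured step covers an exchange of this kind. What the numbers do show is that compound 1 and compound 3, which carry different aromatic groups at this position, give values within the scatter of each other, and the amide portion of compound 4 is the same as in compound 3. The step of a 1.3-fold lower number from compound 3 to compound 4 (0.10 log units; within the scatter) is therefore expected to be none beyond the scatter. The estimate for compound 4 in this assay is 11 uL/min, with a range from 5 uL/min to 24 uL/min.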

Compound 4, intrinsic clearance in a liver preparation (reported as CLH), per the amount of preparation that the assay uses: 13 uL/min
Compound 4: the middle estimate sits 1.2-fold (0.07 log units) below what was measured; measured number inside the range.
By their numbers in this assay, from the lowest: compounds 1, 4 and 3 (each within the scatter of the next); then compound 2.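

In this assay, among these compounds, replacing the 4-fluoro-2-methoxyphenyl group with a group built on a six-membered aromatic ring with 2 hetero atoms gives a 1.1-fold lower number from compound 3 to compound 4 (0.03 log units; within the scatter), and this is the first direct reading of a single change at this aromatic carbon, opposite the ring nitrogen. With the amide portion held the same, the two compounds cannot be told apart on this read-out, although the entering group has 3 hydrogen-bond acceptors where the leaving group has 1 and its ring contains 2 hetero atoms where the other ring is carbon only. The data at hand offer no measurement that would explain this result.

As far as these compounds go, it remains open whether a plain phenyl ring, or an aromatic ring carrying an amine or a carboxylic acid, would also give a number within the scatter at this position. From the compounds shown here alone, it is also open whether this aromatic exchange would give so small a step alongside the pyrrolidin-1-yl amide of compound 2, since this single pair shows it only with the amide portion shared by compound 3 and compound 4.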